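The compounds below may be only part of what the source reports. "The series", "measured", "known", "first", "only" and "open" are said of these compounds alone.

The compounds studied here share the core seen in compound 1 `COc1cccc(/C=C/C(=O)c2ccc(OC)c3c2OC(C)(C)C=C3)c1` and were tested in a functional assay on SK-OV-3 cells (Homo sapiens) for antiproliferative activity, read by MTT assay, with a stated time of 24 h; a lower number here means a stronger inhibitor, a higher number a weaker inhibitor. In this assay compound 1 gives 9360 nM. Compound 2 `COc1ccc(C(=O)/C=C/c2ccc(Br)cc2)c2c1C=CC(C)(C)O2` reaches only a limit of the assay, > 10000 nM. Compound 3 `COc1ccc(C(=O)/C=C/c2ccc(N(c3ccccc3)c3ccccc3)cc2)c2c1C=CC(C)(C)O2` likewise sits at a limit, > 10000 nM. Among the numbers shown, compound 2 stands at the limit (the limit of > 10000 nM in this assay, at which 2 of the 3 values shown sit). Going by the values given here, the single step between measured compounds, an at least 1.0-fold higher number from compound 1 to compound 2 (0.02 log units; that floor lies within the scatter), was a floor that says little about size. Compound 4 `COc1ccc(C(=O)/C=C/c2ccc(-n3ccnc3)cc2)c2c1C=CC(C)(C)O2` differs from compound 2 by 1H-imidazol-1-yl in place of bromo on an aromatic carbon. Among the compounds with values here, no measured step covers this exchange, so no change beyond the scatter is expected. The step that the limit leaves unreadable from compound 2 to compound 4 is expected to stay small. Compound 4 is therefore estimated at 12000 nM, within 4000 nM to 40000 nM.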

Compound 4, half-maximal inhibitory concentration: 7200 nM
Beside the measured number, compound 4's estimate is 1.7-fold (0.22 log units) above it, and the stated range covers the measured number.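

With 1H-imidazol-1-yl in place of bromo on this aromatic carbon, para to a large group, compound 4 gives a measured number where compound 2 gives only a limit. The exchange reads as an at least 1.3-fold lower number from compound 2 to compound 4 (0.14 log units; that floor lies within the scatter). Its true size cannot be read because the value of compound 2 is a limit: the limit of > 10000 nM in this assay, at which 2 of the 4 values shown sit.

On these data alone, what an amine or a carboxylic acid on this aromatic carbon would give remains open. So does whether 1H-pyrazol-1-yl would match 1H-imidazol-1-yl here.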